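The source may hold more compounds than are shown below. What is called first, only, known or untested is meant among the compounds shown, and "the series" means these compounds.

Working notes on the series. In an assay on isolated protein for binding affinity to melanin-concentrating hormone receptor 1 (Homo sapiens) (a higher number here means a weaker inhibitor, a lower number a stronger inhibitor), compound 1 `Cc1ccc(-c2cc3ncn([C@H]4CCN(C(=O)N(C)[C@H]5CCN(C)C5)C4)c(=O)c3s2)cc1` gives 15 nM. Compound 2 `CN1CC[C@H](N(C)C(=O)N2CC[C@H](n3cnc4cc(-c5ccc(OC(F)(F)F)cc5)sc4c3=O)C2)C1` gives 39 nM in this assay, and the step of a 2.6-fold higher number from compound 1 to compound 2 (0.41 log units; beyond the scatter) corresponds to trifluoromethoxy in place of methyl on an aromatic carbon. Compound 3 `Cc1ccc(-c2cc3ncn([C@H]4CCN(C(=O)N(C)[C@H]5CCN(C6CCOCC6)C5)C4)c(=O)c3s2)cc1` gives 14 nM in this assay; the step of a 1.1-fold lower number from compound 1 to compound 3 (0.03 log units; within the scatter), oxan-4-yl in place of methyl on an amine nitrogen in a ring, leaves the number within the scatter. Compound 3 thus holds the lowest of the three numbers, but its gap to compound 1 is within the scatter; only compound 2 stands apart, beyond the scatter.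

Compound 4 `CN(C(=O)N1CC[C@H](n2cnc3cc(-c4ccc(OC(F)(F)F)cc4)sc3c2=O)C1)[C@H]1CCN(C2CCOCC2)C1` is not yet measured. It differs from compound 3 as follows: trifluoromethoxy in place of methyl on an aromatic carbon. Among the compounds with values here, the one measured step that bears on this change is a 2.6-fold higher number from compound 1 to compound 2 (0.41 log units; beyond the scatter), made on the same core carrying methyl rather than oxan-4-yl on the amine nitrogen; since a 1.1-fold lower number from compound 1 to compound 3 (0.03 log units; within the scatter) lay within the scatter, the two changes are taken as independent. The step of a 2.6-fold higher number from compound 3 to compound 4 (0.41 log units; beyond the scatter) is therefore expected to be of similar size, toward a higher number. Compound 4 is estimated at 36 nM in this assay, with a range from 18 nM to 75 nM.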

Compound 4, inhibition constant: 18 nM
For compound 4 the middle estimate is 2.0-fold (0.30 log units) above the measured one; measured number inside the range.
By their numbers in this assay, from the lowest: compounds 3, 1 and 4 (each within the scatter of the next); then compound 2.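

With oxan-4-yl on the amine nitrogen, trifluoromethoxy in place of methyl gives a 1.3-fold higher number from compound 3 to compound 4 (0.11 log units; within the scatter), yet this step cannot be separated from the one seen with methyl on that nitrogen: the same change on two cores in this assay, a 2.6-fold higher number (0.41 log units; beyond the scatter) from compound 1 to compound 2 and a 1.3-fold higher number (0.11 log units; within the scatter) from compound 3 to compound 4, 2.0-fold (0.31 log units) apart, within the scatter of two such steps

Oxan-4-yl in place of methyl, which left the number within the scatter with 4-methylphenyl, gives a 2.2-fold lower number from compound 2 to compound 4 (0.34 log units; beyond the scatter) with 4-(trifluoromethoxy)phenyl, but these two steps also cannot be separated: the same change on two cores in this assay, a 1.1-fold lower number (0.03 log units; within the scatter) from compound 1 to compound 3 and a 2.2-fold lower number (0.34 log units; beyond the scatter) from compound 2 to compound 4, 2.0-fold (0.31 log units) apart, within the scatter of two such steps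

The four compounds therefore fit two independent changes as well as two coupled ones, and with oxan-4-yl present, the swap to trifluoromethoxy leaves compound 4 within the scatter of compound 3.

On these data alone, whether the two places are really coupled remains open, as a further matched set on the shared core would be needed to tell. Also open, as far as these compounds go, is how a chlorine or a nitrile on the aromatic carbon, or an acetyl or a piperidin-4-yl on the amine nitrogen, would behave.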